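This account rests on a few compounds, and the source may have more. Where it says the series, first, only, none or still open, it means among the compounds named here.

Measured compounds in a physicochemical assay for solubility, read by HPLC, using the shake flask method, measured as kinetic solubility, with a stated time of 2 h, at pH 7.4; a lower number here means a less soluble compound, a higher number a more soluble compound:
- compound 1 `Cc1cc(NCc2ccccn2)n2ncc(Br)c2n1`: 89300 nM
- compound 2 `Cc1cc(NCc2ccncc2)n2nc(C)c(-c3ccccc3)c2n1`: 134000 nM
- compound 3 `Cc1cc(NCc2nccs2)n2nc(C)c(-c3ccccc3)c2n1`: 108000 nM

Compound 1 gives the lowest of the three numbers in this assay, though its gaps to compound 3 and to compound 2 both sit within the scatter, so no order among the three can be read.

Compound 4 `Cc1cc(NCc2ccccn2)n2ncc(-c3ccncc3)c2n1` differs from compound 1 by pyridin-4-yl in place of bromo on an aromatic carbon. Within the data shown here, no measured step touches this position; the only step in the set, a 1.2-fold lower number from compound 2 to compound 3 (0.09 log units; within the scatter), concerns the group on the saturated chain carbon and stayed within the scatter. Compounds 2 and 3 carry a phenyl at the position in question and give numbers close to compound 1.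

With nothing bearing directly, the step of a 1.3-fold higher number from compound 1 to compound 4 (0.11 log units; within the scatter) is expected to stay within the scatter. Compound 4 is estimated at 115000 nM, with a range of 55000 nM to 240000 nM.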

Compound 4, solubility: 161000 nM
The estimate for compound 4 lay 1.4-fold (0.15 log units) below the measured number, within the range that was stated.
By their numbers in this assay, from the lowest: compounds 1, 3, 2 and 4 (each within the scatter of the next).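

At this aromatic carbon, the change from bromo to pyridin-4-yl gives a 1.8-fold higher number from compound 1 to compound 4 (0.26 log units; within the scatter) in this assay. Among these compounds, this is the first direct reading at this position, and a ring with more heavy atoms in place of a single bromine leaves the step within the scatter. Nothing at hand offers an explanation for this step.

Open, as far as these compounds go, is whether a carboxylic acid or a morpholine at this aromatic carbon would give a step beyond the scatter. Also open, from the compounds shown here alone, is how phenyl reads here against bromo or pyridin-4-yl, since compound 2 and compound 3 differ from compound 1 and compound 4 in more than one place.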